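Varying the aryl group on the thioether of a diamine core

This account rests on a few compounds, and the source may have more. Where it says the series, first, only, none or still open, it means among the compounds named here.

Measured in a functional assay on NCI/ADR-RES cells (Homo sapiens) for inhibition, read by sulforhodamine B assay, with a stated time of 48 h; a higher number here means a weaker inhibitor of growth, a lower number a stronger inhibitor of growth:
compound 1, `Nc1cc(N)c2nc(-c3ccccc3)c(NCc3ccc(F)cc3)nc2c1`, gives 2450 nM
compound 2, `COc1ccc(Sc2nc3cc(N)cc(N)c3nc2-c2ccccc2)cc1`, gives only a limit, < 100000 nM
compound 3, `Nc1cc(N)c2nc(-c3ccccc3)c(Sc3ccc(Cl)c(Cl)c3)nc2c1`, gives 19100 nM

Compound 3 holds the higher of the two readable numbers; the step of a 7.8-fold higher number from compound 1 to compound 3 (0.89 log units; beyond the scatter) separates it from compound 1. Compound 2 sits at the limit (the limit of < 100000 nM in this assay, at which 1 of the 3 values shown sits), so its value is not a number.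

Compound 4, `Nc1cc(N)c2nc(-c3ccccc3)c(Sc3ccc(F)cc3)nc2c1`, differs from compound 3 by 4-fluorophenyl in place of 3,4-dichlorophenyl on a sulfur. Going by the values given here, the only measured step that changes the group on the sulfur is a step that the limit leaves unreadable from compound 2 to compound 3, and the limit leaves it unreadable, so no measured step tells how large this change should be. Compound 4 is therefore expected to stay near compound 3, with a step of a 1.0-fold higher number from compound 3 to compound 4 (0.02 log units; within the scatter) that need not exceed the scatter; the estimate for compound 4 is 20000 nM, within 6000 nM to 70000 nM.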

Compound 4, concentration for 50% growth inhibition: 16600 nM
For compound 4 the middle estimate is 1.2-fold (0.08 log units) above the measured one, and the stated range covers the measured number.
By their numbers in this assay, from the lowest: compound 1; then compounds 4 and 3 (each within the scatter of the next).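

In this assay, going by these compounds alone, the first readable change of the aryl group on the sulfur gives a 1.2-fold lower number from compound 3 to compound 4 (0.06 log units; within the scatter) and so does not separate 4-fluorophenyl from 3,4-dichlorophenyl. Replacing (4-fluorobenzyl)amino with (4-fluorophenyl)sulfanyl gives a 6.8-fold higher number from compound 1 to compound 4 (0.83 log units; beyond the scatter) and repeats the gap seen with compound 3. Steps involving compound 2 cannot be read, since its value is only a limit: the limit of < 100000 nM in this assay, at which 1 of the 4 values shown sits.

Still open, going by these compounds, is whether that gap follows from the sulfur or from the missing methylene, which a (4-fluorobenzyl)sulfanyl group would separate. A longer alkyl chain or a carboxylic acid on the sulfur also remains untested among the compounds shown.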